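The compounds below may be only part of what the source reports. "The series", "measured", "known", "first", "only" and "open" are said of these compounds alone.

Compound 1 `COc1ccc(/C=C/C(=O)c2sc(Nc3ccc(Cl)cc3)nc2C)cc1` and compound 2 `COc1cccc(/C=C/C(=O)c2sc(Nc3ccc(Cl)cc3)nc2C)c1` share one core and differ only in the methoxyphenyl on the double-bonded chain carbon. In a functional assay on NCI-H460 cells (Homo sapiens) for cytotoxicity, read by MTT assay (a lower number here means a stronger inhibitor, a higher number a weaker inhibitor), compound 1 gives > 25000 nM, which is a limit of the assay rather than a number. In this assay compound 2 likewise gives > 25000 nM, again a limit. The step that the two limits leave unreadable from compound 1 to compound 2 cannot be read since both ends sit at the limit of > 25000 nM in this assay, at which 2 of the 2 values shown sit. Compound 2 thus stands only at a limit; no number places it. Compound 3 `COc1cccc(/C=C/C(=O)c2sc(Nc3ccc(Cl)c(Cl)c3)nc2C)c1` is the next step: chloro in place of hydrogen on an aromatic carbon, on an aromatic carbon of a six-membered aromatic ring of carbon only, ortho to a chloro group and meta to a large group, so that 4-chlorophenyl becomes 3,4-dichlorophenyl and (4-chlorophenyl)amino becomes (3,4-dichlorophenyl)amino. Among the measured compounds shown here, the only measured step, a step that the two limits leave unreadable from compound 1 to compound 2, concerns a different part of the molecule and is itself unreadable, so it gives no size to expect in this assay for the new chloro. With compound 2 at a limit, the expected step that the limit leaves unreadable from compound 2 to compound 3 is anchored to no number in either direction. Compound 3 is therefore expected to remain at or near the limit, estimated at 30000 nM with a range from 8000 nM to 100000 nM.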

Compound 3, half-maximal inhibitory concentration: 20100 nM
Estimate against measurement, compound 3: 1.5-fold (0.17 log units) above, and the stated range covers the measured number.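

In this assay, among the compounds shown here, compound 3 gives 20100 nM, the first reading in this short series that is a number and not a limit, and it comes with the change from (4-chlorophenyl)amino to (3,4-dichlorophenyl)amino. The chloro in place of hydrogen, ortho to a chloro group and meta to a large group, is recorded as an at least 1.2-fold lower number from compound 2 to compound 3 (0.09 log units; that floor lies within the scatter), so the floor of this step does not separate the two compounds from ordinary scatter, although the true size could be larger. The step between the two methoxyphenyl isomers still cannot be read, and the series rests largely on limits: the limit of > 25000 nM in this assay, at which 2 of the 3 values shown sit.

Open, going by these compounds, is whether this response belongs to chloro in particular or would also appear with a fluoro, a methyl or a trifluoromethyl group at the same place in this assay. Also open, on these data alone, is how the 3-methoxyphenyl and 4-methoxyphenyl ends compare when the other end of the molecule carries the (3,4-dichlorophenyl)amino group, where a number at both ends could make that comparison readable.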